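Taking the Methyl off the Aryl Group of Compound 1

The source may report more compounds than this note shows. Statements on the series, on what has been measured and on what is new or still open speak of the compounds shown alone.

Measured compounds:
Compound 1, `Cc1ccc(-c2nc3c(c(-c4ccccc4)nn3-c3ccccc3)c(-c3ccc(O)cc3)c2C#N)cc1`: 3300 nM
Compound 2, `COc1cc(-c2c(C#N)c(-c3cccs3)nc3c2c(-c2ccccc2)nn3-c2ccccc2)ccc1O`: 44200 nM

In a functional assay on MV4-11 cells (Homo sapiens) for antiproliferative activity, read by resazurin assay, with a stated time of 72 h (a lower number here means a stronger inhibitor, a higher number a weaker inhibitor), compound 1 gives 3300 nM, the lower of the two numbers shown. Compound 2, with its different aryl group and substituted phenol, gives 44200 nM in this assay, a gap beyond the usual scatter. Compound 3 `N#Cc1c(-c2ccccc2)nc2c(c(-c3ccccc3)nn2-c2ccccc2)c1-c1ccc(O)cc1` is the unmeasured partner of compound 1; it differs from compound 1 by hydrogen in place of methyl on an aromatic carbon. Going by the values given here, no pair of measured compounds isolates this change, so its size cannot be read off from the data. A single methyl removed at this position is, in the account given here, expected to produce no step beyond the scatter, or at most a modest rise in number, the step from compound 1 to compound 3 being estimated as a 1.4-fold higher number from compound 1 to compound 3 (0.13 log units; within the scatter). Compound 3 is therefore expected to give about 4500 nM in this assay, with a range from 1500 nM to 14000 nM.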

Compound 3, half-maximal inhibitory concentration: 26100 nM
The estimate for compound 3 lay 5.8-fold (0.76 log units) below the measured number, outside the stated range (above it).
By their numbers in this assay, from the lowest: compound 1; then compounds 3 and 2 (each within the scatter of the next).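

Removing this one methyl is not a neutral change: in this assay, the change from 4-methylphenyl to phenyl gives a 7.9-fold higher number from compound 1 to compound 3 (0.90 log units; beyond the scatter), which lies beyond the scatter. Going by these compounds alone, this is the first measured pair here to differ in one place, and it shows that a single methyl on this aromatic carbon, para to a large group, is enough to shift the number by more than the scatter. Nothing measured here accounts for the size of this step.

From the compounds shown here alone, it remains open whether an ethyl group, a methoxy group or a chlorine atom at this place would match the methyl of compound 1 or lower the number further. Going by these compounds, it is equally open whether an amine or a carboxylic acid here would be tolerated, and whether the methyl would have the same effect if the phenol of compound 1 carried other substituents.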